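Swapping one fluoro for hydrogen on compound 2

The compounds below may be only part of what the source reports. "The series", "measured", "known", "first", "only" and "open" are said of these compounds alone.

Measured in an ADME assay on microsomes from liver (Rattus norvegicus) for metabolic stability, read by LC-MS, using NADPH, with a stated time of 10 min, tested at 0.5 uM; a lower number here means that less of the compound is left, a higher number that more of the compound is left:
Compound 1 `CC(=O)Nc1cc(-c2ccc(OC[C@@](C)(N)CC(C)C)c(F)c2)ccn1`: 92%
Compound 2 `CC(=O)Nc1cc(-c2cc(F)c(OC[C@@H](N)CC(C)C)c(F)c2)ccn1`: 100%

The values of compound 2 and compound 1 lie within the usual scatter of each other, and both are high. Compound 3 `CC(=O)Nc1cc(-c2ccc(OC[C@@H](N)CC(C)C)c(F)c2)ccn1` has hydrogen in place of fluoro on an aromatic carbon. Among the compounds with values here, no measured pair shows this change alone, so the expectation rests on the two values, 100% for compound 2 and 92% for compound 1. The expected result is a number 8 percentage points lower from compound 2 to compound 3 (within the scatter), a small fall that stays within the scatter. For compound 3 the estimated value is 92%, with an expected range from 78% to 100%.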

Compound 3, percent of the compound remaining: 80%
Compound 3: the middle estimate sits 12 percentage points above what was measured; measured number inside the range.
By their numbers in this assay, from the lowest: compound 3; then compounds 1 and 2 (each within the scatter of the next).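

In this assay the fluoro ortho to the (2-amino-4-methylpentyl)oxy group matters: hydrogen in its place gives a number 20 percentage points lower from compound 2 to compound 3 (beyond the scatter) and so is a real loss. The chain matters too, since 1-amino-3-methylbutyl in place of 1-amino-1,3-dimethylbutyl gives a number 12 percentage points lower from compound 1 to compound 3 (beyond the scatter) as well. Either feature alone thus leaves more of the compound than compound 3 keeps. As far as these compounds go, whether chloro or methoxy on that aromatic carbon would hold the value as fluoro does stays open. So does the cause of both steps, on which no measurement here bears.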